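Back from the pyrazolyl to a phenyl: solubility outlook

The compounds below may be only part of what the source reports. "The series", "measured", "known", "first", "only" and "open" are said of these compounds alone.

Compound 3 `Cc1cc(NCc2ccccn2)n2ncc(-c3ccn(C)n3)c2n1` is the only one of the three measured compounds that gives a number: in a physicochemical assay for solubility, read by HPLC, using the shake flask method, measured as kinetic solubility, with a stated time of 2 h, at pH 7.4 (on this read-out lower numbers stand for lower solubility and higher numbers for higher solubility), compound 3 gives 188000 nM. Compound 1 `Cc1cc(NCc2ccccn2)n2ncc(-c3cccc(Cl)c3)c2n1` sits at the limit of < 5000 nM in this assay, at which 2 of the 3 values shown sit, so its value of < 5000 nM is a limit of the assay and not a number. Compound 2 `Cc1cc(NCc2ccccn2)n2ncc(-c3ccc(F)c(Cl)c3)c2n1` likewise returns only a limit, < 5000 nM. The unmeasured compound 4 `Cc1cc(NCc2ccccn2)n2ncc(-c3cccc(N(C)C)c3)c2n1` carries 3-(dimethylamino)phenyl in place of 1-methyl-1H-pyrazol-3-yl on an aromatic carbon. For the measured compounds named here, two measured steps bear on this change, both running toward compound 3: an at least 37-fold higher number from compound 1 to compound 3 (1.57 log units; beyond the scatter) and an at least 37-fold higher number from compound 2 to compound 3 (1.57 log units; beyond the scatter). Going by the values given here, compound 4 moves in the opposite direction, exchanging the 1-methyl-1H-pyrazol-3-yl for a 3-(dimethylamino)phenyl, so a large fall in this assay is expected, although no measured compound carries this particular phenyl and the exact size is uncertain. Compound 4 is therefore estimated at about 12000 nM, within a range of 2500 nM to 60000 nM. This expected step amounts to a 16-fold lower number from compound 3 to compound 4 (1.19 log units; beyond the scatter), and there is a fair chance that only a limit is reported.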

Compound 4, solubility: 94600 nM
Estimate against measurement, compound 4: 7.9-fold (0.90 log units) below, outside the stated range (above it).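

In this assay, a phenyl on this aromatic carbon does not by itself bring the read-out down: 3-(dimethylamino)phenyl in place of 1-methyl-1H-pyrazol-3-yl gives a 2.0-fold lower number from compound 3 to compound 4 (0.30 log units; within the scatter), so compound 3 and compound 4 cannot be told apart here. Among the phenyl compounds the substituent decides the outcome, with dimethylamino in place of chloro giving an at least 18-fold higher number from compound 1 to compound 4 (1.27 log units; beyond the scatter) and 3-(dimethylamino)phenyl in place of 3-chloro-4-fluorophenyl giving an at least 18-fold higher number from compound 2 to compound 4 (1.27 log units; beyond the scatter). Both of these steps start from a limit and not from a number: the limit of < 5000 nM in this assay, at which 2 of the 4 values shown sit.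

The compounds shown do not tell whether a morpholine, a methoxy group or a carboxylic acid in place of the dimethylamino would read like compound 4. They also leave open how an unsubstituted phenyl would read.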